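The source may report more compounds than this note shows. Statements on the series, on what has been measured and on what is new or still open speak of the compounds shown alone.

Measured in a functional assay on HepG2 cells (Homo sapiens) for antiproliferative activity, read by MTT assay, with a stated time of 48 h; on this read-out higher numbers stand for weaker inhibition and lower numbers for stronger inhibition:
Compound 1 `O=C(CN1CCCC1)Nc1ccc2ncnc(Nc3cccc(C(F)(F)F)c3)c2c1`: 25200 nM
Compound 2 `O=C(CN1CCCC1)Nc1ccc2ncnc(Nc3ccc(Br)cc3)c2c1`: > 100000 nM, a limit
Compound 3 `CN1CCN(CC(=O)Nc2ccc3ncnc(Nc4ccc(Br)cc4)c3c2)CC1`: > 100000 nM, a limit

Compound 2 has no number, only the limit > 100000 nM. The same holds for compound 3, as the limit of > 100000 nM in this assay, at which 2 of the 3 values shown sit, shows. Compound 4 `O=C(CN1CCCC1)Nc1ccc2ncnc(Nc3ccc(OCc4cccc(F)c4)cc3)c2c1` differs from compound 2 in one place: (3-fluorobenzyl)oxy in place of bromo on an aromatic carbon.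

Among the compounds with values here, two measured steps bear on this. The step of an at least 3.9-fold higher number from compound 1 to compound 2 (0.59 log units; beyond the scatter) changed the group on the same aromatic ring as the bromo and lies beyond the scatter. The step that the two limits leave unreadable from compound 2 to compound 3 was made elsewhere and gives no size. A modest move towards lower numbers in this assay is therefore expected, although compound 4 may also stay at the limit. The expected step is an at least 3.3-fold lower number from compound 2 to compound 4 (0.52 log units; beyond the scatter). Compound 4 is estimated at 30000 nM, within an expected range of 8000 nM to 100000 nM.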

Compound 4, half-maximal inhibitory concentration: 25100 nM
Estimate against measurement, compound 4: 1.2-fold (0.08 log units) above; low and high end bracket the measured number.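

At this aromatic carbon, (3-fluorobenzyl)oxy in place of bromo, with 9 heavy atoms and an added aromatic ring entering for a single bromine, moves the result in this assay off the limit: an at least 3.9-fold lower number from compound 2 to compound 4 (0.60 log units; beyond the scatter). A far larger group is therefore compatible with a measurable number at this carbon. The true size of the step stays unknown because compound 2 has only a limit: the limit of > 100000 nM in this assay, at which 2 of the 4 values shown sit.

On these data alone, whether the ether oxygen or the fluorobenzyl ring matters more remains open. So does the outcome with a methoxy group or an amine at this carbon.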